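Swapping the Indole of Compound 2 for a Chlorophenyl

The compounds below may be only part of what the source reports. "The series", "measured", "known", "first", "only" and "open" are said of these compounds alone.

Of the compounds shown here, three sharing one core have been tested in a functional assay on DU-145 cells (Homo sapiens) for inhibition, read by trypan blue exclusion, with a stated time of 96 h; a higher number here means a weaker inhibitor of growth, a lower number a stronger inhibitor of growth. Compound 2 `Cc1ccc(CS/C(=C/c2c[nH]c3ccc(Cl)cc23)C(=O)c2ccc(Cl)cc2)cc1` gives 1000 nM, the lowest number of the three. Compound 1 `CCOc1ccc(/C=C(\C(=O)c2ccc(Cl)cc2)S(=O)(=O)Cc2ccc(C)cc2)cc1OC` gives 10000 nM, and compound 3 `Cc1ccsc1/C=C(/SCc1ccc(Cl)c(Cl)c1)C(=O)c1ccc(Cl)cc1` gives 50000 nM; both sit beyond the scatter above compound 2, so compound 2 is the strongest inhibitor of growth here.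

Compound 4 `Cc1ccc(CS/C(=C/c2ccc(Cl)cc2)C(=O)c2ccc(Cl)cc2)cc1` is not yet measured. It differs from compound 2 by a single change: 4-chlorophenyl in place of 5-chloro-1H-indol-3-yl on a double-bonded chain carbon bound to a double-bonded chain carbon. Since compound 1, which carries another aromatic ring at that place, reaches only 10000 nM, and compound 3, which also carries another aromatic ring at that place, reaches only 50000 nM, the step from compound 2 is expected to go upward, toward weaker inhibition, as a 5.0-fold higher number from compound 2 to compound 4 (0.70 log units; beyond the scatter). Compound 4 is therefore estimated at 5000 nM, within a range from 1000 nM to 30000 nM.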

Compound 4, concentration for 50% growth inhibition: 10000 nM
Compound 4: middle estimate off by 2.0-fold (0.30 log units), on the low side, within the range that was stated.
By their numbers in this assay, from the lowest: compound 2; then compounds 1 and 4 (each within the scatter of the next); then compound 3.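

In this assay, going by these compounds alone, 4-chlorophenyl in place of 5-chloro-1H-indol-3-yl gives a 10-fold higher number from compound 2 to compound 4 (1.00 log units; beyond the scatter), and this is the first pair here that differs in one place only, so the effect of this position can now be read directly. The change removes the five-membered aromatic ring and the hydrogen-bond donor together, and this pair cannot separate the two. Nothing available explains the step. Open, going by these compounds, is what an amine or a carboxylic acid at this same place would give, and whether 5-chloro-1H-indol-3-yl would also give the lower number on the core of compound 1.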